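From Sec-Butyl to Allyl on the Shared Core

A few compounds are considered here, and "the series" means these few. Any claim that something is new, unique, unknown or untested is made for them only; others in the source may bear on it.

In a functional assay on the whole organism (strain Sprague-Dawley) for inhibition, with Rattus norvegicus as the target, with a stated time of 10 min (a lower number here means that less compound is needed, a higher number that more compound is needed for the effect), compound 3 (`CCC(C)Oc1ccccc1-c1ncc(C(=O)O)c(=O)[nH]1`) gives 0.5 mg/kg and stands level with compound 2 (`CCCCOc1ccccc1-c1ncc(C(=O)O)c(=O)[nH]1`), which gives 0.5 mg/kg as well. Together these are the lowest of the three numbers. Compound 1 (`COc1ccccc1-c1ncc(C(=O)O)c(=O)[nH]1`) stands apart at 10 mg/kg on the same scale.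

The next change leads to compound 4 (`C=CCOc1ccccc1-c1ncc(C(=O)O)c(=O)[nH]1`), with allyl in place of sec-butyl on an oxygen on an aromatic ring. Among the measured compounds shown here, no allyl compound has been measured yet, so the expectation rests on three steps at that oxygen. The data show a 20-fold lower number from compound 1 to compound 2 (1.30 log units; beyond the scatter) when the methoxy compound gains propyl in place of hydrogen. They also show a 20-fold lower number from compound 1 to compound 3 (1.30 log units; beyond the scatter) with sec-butyl in place of methyl, and both steps are large and lie beyond the scatter. Butyl and sec-butyl do not separate, with no change at the digits printed from compound 2 to compound 3 (within the scatter) between them.

Allyl is a shorter chain than butyl and a longer one than methyl, so it falls between the chains of compound 1 and compound 2. In this assay a moderate rise is therefore expected, an estimated 3.0-fold higher number from compound 3 to compound 4 (0.48 log units; beyond the scatter) and thus well short of the full gap to compound 1. Compound 4 is expected at 1.5 mg/kg within an estimated range of 0.4 mg/kg to 6 mg/kg on this dose scale.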

Compound 4, dose for 50% inhibition: 0.5 mg/kg
Estimate against measurement, compound 4: 3.0-fold (0.48 log units) above; the measured number falls inside the stated range.
By their numbers in this assay, from the lowest: compounds 2, 3 and 4 (each within the scatter of the next); then compound 1.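

In this assay, putting allyl in place of sec-butyl on the oxygen on an aromatic ring gives no change at the digits printed from compound 3 to compound 4 (within the scatter), and the comparison with the butyl compound likewise gives no change at the digits printed from compound 2 to compound 4 (within the scatter). The large step away from the methoxy compound, a 20-fold lower number from compound 1 to compound 4 (1.30 log units; beyond the scatter), therefore does not need a saturated group at this oxygen: allyl, with 3 carbon atoms and 1 double bond outside aromatic rings, matches what butyl and sec-butyl show. Among the listed compounds, compounds 2, 3 and 4 stand together and compound 1 alone stands apart, so neither branching, the double bond nor the smaller allyl group separates the three larger groups at this position.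

Allyl differs from sec-butyl in both chain length and saturation, so the two changes cannot be told apart here, and a saturated propyl or an ethyl group on the same oxygen would be needed to show how short the chain can become before the number moves toward that of compound 1. A longer chain such as hexyl, or a chain ending in an amine, also remains open, and nothing at hand accounts for why these groups stand level.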